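A few compounds are considered here, and "the series" means these few. Any claim that something is new, unique, unknown or untested is made for them only; others in the source may bear on it.

Measured so far in a functional assay on PC-3 cells (Homo sapiens) for inhibition; a lower number here means a stronger inhibitor, a higher number a weaker inhibitor:
compound 1 `COc1cc2nc(N3CCN(C(=O)OCc4ccccc4)CC3)nc(N)c2cc1OC`, 63000 nM
compound 2 `COc1cc2nc(N3CCN(C(=O)c4ccc(C(F)(F)F)cc4)CC3)nc(N)c2cc1OC`, > 100000 nM, which is a limit of the assay and not a number
compound 3 `COc1cc2nc(N3CCN(S(=O)(=O)c4ccc(Cl)s4)CC3)nc(N)c2cc1OC`, 25000 nM

Compound 3 gives the lowest of the two numbers; the step of a 2.5-fold lower number from compound 1 to compound 3 (0.40 log units; beyond the scatter) is modest but beyond the scatter. Compound 2 sits at the limit of > 100000 nM in this assay, at which 1 of the 3 values shown sits. Compound 4 `COc1cc2nc(N3CCN(S(=O)(=O)c4ccc(S(C)(=O)=O)cc4)CC3)nc(N)c2cc1OC` differs from compound 3 by 4-(methylsulfonyl)phenyl in place of 5-chlorothiophen-2-yl on a sulfonyl sulfur. Within the data shown here, no measured step alters the group on a sulfonyl sulfur. The nearest comparison is an at least 1.5-fold higher number from compound 1 to compound 2 (0.20 log units; that floor lies within the scatter), where a new aromatic group on a carbonyl carbon weakened inhibition, while a 2.5-fold lower number from compound 1 to compound 3 (0.40 log units; beyond the scatter) changed the linking group itself. On that basis a small loss, or no change beyond the scatter, is expected in this assay. Compound 4 is therefore estimated at 40000 nM, between 15000 nM and 100000 nM, an expected step of a 1.6-fold higher number from compound 3 to compound 4 (0.20 log units; within the scatter).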

Compound 4, half-maximal inhibitory concentration: 17000 nM
For compound 4 the middle estimate is 2.4-fold (0.37 log units) above the measured one; the measured number falls inside the stated range.
By their numbers in this assay, from the lowest: compounds 4 and 3 (each within the scatter of the next); then compound 1. At a limit, above all of these: compound 2.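

In this assay, placing 4-(methylsulfonyl)phenyl in place of 5-chlorothiophen-2-yl on a sulfonyl sulfur gives a 1.5-fold lower number from compound 3 to compound 4 (0.17 log units; within the scatter) and so leaves the two compounds indistinguishable. This position therefore accepts either a five-membered aromatic ring with chlorine or a six-membered carbon ring carrying methylsulfonyl, with no measurable difference in this assay. Nothing measured here explains why the two groups read alike. Still open, on these data alone, is how a simple methyl group on the sulfonyl sulfur would compare, and whether a phenyl ring carrying an amine or a carboxylic acid would change the number.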